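Adding a phenyl to compound 1: working notes

The source may hold more compounds than are shown below. What is called first, only, known or untested is meant among the compounds shown, and "the series" means these compounds.

Among the measured compounds shown here, in a functional assay on A-375 cells (Homo sapiens) for antiproliferative activity, read by MTT assay, with a stated time of 72 h (on this read-out lower numbers stand for stronger inhibition and higher numbers for weaker inhibition), compound 1 `O=C1COc2ccc(-c3cccc(NS(=O)(=O)c4ccc(F)cc4)c3)cc2N1` gives 20100 nM as the only exact number so far. Compound 2 `COc1ncc(-c2ccc3c(c2)N(c2ccc(F)cc2)C(=O)CO3)cc1NS(=O)(=O)c1ccc(F)cc1` reads > 40000 nM and that value is a limit of the assay. Compound 3 `O=C1COc2ccc(-c3cccc(NS(=O)(=O)c4ccc(F)cc4)c3)cc2N1c1ccccc1` follows from compound 1 by phenyl in place of hydrogen on an amide-type nitrogen in a ring with phenyl in place of hydrogen on an amide-type nitrogen in a ring. For the measured compounds named here, no measured step covers this change, so the expectation in this assay is a 1.3-fold lower number from compound 1 to compound 3 (0.13 log units; within the scatter) and no shift beyond the usual scatter. The estimated value for compound 3 is 15000 nM with 5000 nM to 40000 nM as its expected range.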

Compound 3, half-maximal inhibitory concentration: > 40000 nM
Compound 3: only a limit was reported; the forecaster's own chance of this, stated with the estimate: 25%; middle value at least 2.6-fold (0.42 log units) away from the limit.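

Phenyl in place of hydrogen on the amide-type nitrogen in the ring gives an at least 1.9-fold higher number from compound 1 to compound 3 (0.29 log units; that floor lies within the scatter). Among the compounds shown here, this is the first direct reading at this position, and the number does not fall with the phenyl. The step is only a floor, since compound 3 reads as a limit of the assay: the limit of > 40000 nM in this assay, at which 2 of the 3 values shown sit.

As far as these compounds go, whether methyl or an aminoethyl chain on this nitrogen would give an exact number remains open. From the compounds shown here alone, how far the phenyl really moves the number also remains open, as does whether any group here can lower it.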